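The compounds below may be only part of what the source reports. "The series", "measured", "known", "first", "only" and "open" are said of these compounds alone.

Measured so far in an ADME assay on Huh-7 cells (Homo sapiens) for cytotoxicity; on this read-out higher numbers stand for weaker inhibition and lower numbers for stronger inhibition:
compound 1 `CN(c1cc2ncc(=O)[nH]c2cc1NC(=S)NC(=O)c1ccco1)C1CCCCC1` gives 17300 nM;
compound 2 `CN(c1cc2ncc(=O)[nH]c2cc1NC(=S)NC(=O)c1ccc(Cl)nc1)C1CCCCC1` gives 34500 nM;
compound 3 `CN(c1cc2ncc(=O)[nH]c2cc1NC(=S)Nc1cccc(C(F)(F)F)c1)C1CCCCC1` gives 78400 nM.

Compound 3 holds the highest number of the three: the nearest is compound 2, with a 2.3-fold higher number from compound 2 to compound 3 (0.36 log units; beyond the scatter), the furthest compound 1, with a 4.5-fold higher number from compound 1 to compound 3 (0.66 log units; beyond the scatter). Compound 4 `CN(c1cc2ncc(=O)[nH]c2cc1NC(=S)Nc1cccc2ccccc12)C1CCCCC1` carries naphthalen-1-yl in place of 3-(trifluoromethyl)phenyl on an amide-type nitrogen. Both measured steps at this nitrogen replaced a carbonyl-linked group with a directly attached aromatic ring and were modest, while the exchange of carbonyl-linked groups, a 2.0-fold higher number from compound 1 to compound 2 (0.30 log units; within the scatter), stayed within the scatter. For the measured compounds named here, no measured step exchanges one aromatic ring for another, so no direction is indicated. For compound 4 a step of a 1.1-fold lower number from compound 3 to compound 4 (0.05 log units; within the scatter) is expected, nothing beyond the scatter. Compound 4 is estimated at 70000 nM, within 30000 nM to 160000 nM.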

Compound 4, half-maximal inhibitory concentration: 43600 nM
Compound 4: the middle estimate sits 1.6-fold (0.21 log units) above what was measured, and the stated range covers the measured number.
By their numbers in this assay, from the lowest: compounds 1, 2, 4 and 3 (each within the scatter of the next, the first and the last beyond it).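

In this assay, the exchange of one directly attached aromatic ring for another at this amide-type nitrogen, naphthalen-1-yl for 3-(trifluoromethyl)phenyl, stays within the scatter (a 1.8-fold lower number from compound 3 to compound 4 (0.25 log units; within the scatter)). Naphthalen-1-yl also stays within the scatter against (6-chloropyridin-3-yl)carbonyl (a 1.3-fold higher number from compound 2 to compound 4 (0.10 log units; within the scatter)) and passes it only against (furan-2-yl)carbonyl (a 2.5-fold higher number from compound 1 to compound 4 (0.40 log units; beyond the scatter)), so compound 4 does not separate from both carbonyl-linked groups as compound 3 does. No measurement on hand accounts for these numbers.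

Open, on these data alone, is how this nitrogen responds to a non-aromatic substituent such as a short alkyl chain, or to an aromatic ring carrying an amine or a carboxylic acid.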